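The compounds below may be only part of what the source reports. "The series", "measured", "known", "first", "only" and "open" are said of these compounds alone.

Values so far in a functional assay on A549 cells (Homo sapiens) for cytotoxicity, read by MTT assay, with a stated time of 72 h; a higher number here means a weaker inhibitor, a lower number a stronger inhibitor:
- compound 1 `CNC(=O)c1cc(Oc2ccc(NC(=O)c3cc(-c4ccc(Br)cc4)ncn3)cc2F)ccn1`: > 100000 nM (a limit, not a number)
- compound 2 `CNC(=O)c1cc(Oc2ccc(NC(=O)c3cc(-c4ccc(C)cc4)ncn3)cc2F)ccn1`: 13200 nM

In this assay, among the measured compounds shown here, compound 2 gives 13200 nM as the only true number so far. Compound 1 stands at > 100000 nM and that is a limit of the assay.

The next compound, compound 3 `CNC(=O)c1cc(Oc2ccc(NC(=O)c3cc(-c4ccc(OC)cc4)ncn3)cc2F)ccn1`, carries methoxy in place of methyl on an aromatic carbon, para to a large group (methoxy in place of methyl on an aromatic carbon). For the measured compounds named here, one measured step touches the same place: methyl in place of bromo gave an at least 7.5-fold lower number from compound 1 to compound 2 (0.87 log units; beyond the scatter) and so shows that a change there can move the value. Going by the values given here, that step rests on a limit, however, and no measured compound carries methoxy, so it gives no direction for this change.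

The expected change is a 1.1-fold higher number from compound 2 to compound 3 (0.06 log units; within the scatter) in this assay, with no shift beyond the scatter expected in either direction. Compound 3 is estimated at 15000 nM, with an expected range from 5000 nM to 50000 nM in this assay.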

Compound 3, half-maximal inhibitory concentration: 34500 nM
Compound 3: middle estimate off by 2.3-fold (0.36 log units), on the low side, and the stated range covers the measured number.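

In this assay, among the compounds shown here, the change from methyl to methoxy gives the first comparison at this position between two true numbers: a 2.6-fold higher number from compound 2 to compound 3 (0.42 log units; beyond the scatter). Methoxy also stands apart from bromo, with an at least 2.8-fold lower number from compound 1 to compound 3 (0.46 log units; beyond the scatter), so all three groups now differ beyond the scatter and methyl gives the lowest number of the three. The size of that second step is only a minimum, as is that of the step from bromo to methyl, since the value of compound 1 is a limit and not a number: the limit of > 100000 nM in this assay, at which 1 of the 3 values shown sits.

Where other groups on the same aromatic carbon would fall remains open, for example a chloro, a hydroxyl or an amine. Three groups also cannot tell why the values fall in this order, and a longer chain such as ethoxy would be needed to show how far the rise from methyl to methoxy continues.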